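A few compounds are considered here, and "the series" means these few. Any claim that something is new, unique, unknown or untested is made for them only; others in the source may bear on it.

Measured in a functional assay on MCF7 cells (Homo sapiens) for cytotoxicity, read by fluorescence, with a stated time of 72 h; on this read-out higher numbers stand for weaker inhibition and lower numbers for stronger inhibition:
Compound 1 `CC(C)c1n[nH]c2c(NCc3ccc(-c4ccccn4)cc3)nc(NCCO)nc12`: 51 nM
Compound 2 `CC(C)c1n[nH]c2c(NCc3ccc(-c4ccccn4)cc3)nc(N[C@@H]3CCCC[C@H]3N)nc12`: 295 nM
Compound 3 `CC(C)c1n[nH]c2c(NCc3ccc(-c4ccccn4)cc3)nc(NCC(N)CO)nc12`: 310 nM

Compound 3 stands at the upper end of these values, with a 1.1-fold higher number from compound 2 to compound 3 (0.02 log units; within the scatter) and a 6.1-fold higher number from compound 1 to compound 3 (0.78 log units; beyond the scatter). The next compound, compound 4 `CC(C)c1n[nH]c2c(NCc3ccc(-c4ccccn4)cc3)nc(N[C@H]3CC[C@H](N)CC3)nc12`, carries 4-aminocyclohexyl in place of 2-amino-3-hydroxypropyl on a nitrogen on an aromatic ring. The nearest guide is the 2-aminocyclohexyl of compound 2, which gave a 5.8-fold higher number from compound 1 to compound 2 (0.76 log units; beyond the scatter). Within the data shown here, the exchange of that group for the one in compound 3 gave only a 1.1-fold higher number from compound 2 to compound 3 (0.02 log units; within the scatter). Among the measured compounds shown here, no measured compound carries 4-aminocyclohexyl, so the range stays wide. The expected result in this assay is no shift beyond the scatter, with an estimated 1.2-fold lower number from compound 3 to compound 4 (0.09 log units; within the scatter). For compound 4 the estimated value is 250 nM, within a range of 90 nM to 700 nM.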

Compound 4, half-maximal inhibitory concentration: 474 nM
Compound 4: the middle estimate sits 1.9-fold (0.28 log units) below what was measured; the measured number falls inside the stated range.
By their numbers in this assay, from the lowest: compound 1; then compounds 2, 3 and 4 (each within the scatter of the next).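

In this assay, the exchange of 2-aminocyclohexyl for 4-aminocyclohexyl on this nitrogen stays within the scatter, with a 1.6-fold higher number from compound 2 to compound 4 (0.21 log units; within the scatter), and so does the exchange of 2-amino-3-hydroxypropyl, with a 1.5-fold higher number from compound 3 to compound 4 (0.18 log units; within the scatter). The three amine-bearing groups therefore cannot be told apart here, whether the group is cyclic or open-chain, while the exchange of 2-hydroxyethyl for 4-aminocyclohexyl lies beyond the scatter, with a 9.3-fold higher number from compound 1 to compound 4 (0.97 log units; beyond the scatter). Nothing available explains this separation.

The compounds shown leave open whether an unsubstituted cyclohexyl or a 3-hydroxypropyl chain would stay close to compound 1 or join the other three.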